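This account rests on a few compounds, and the source may have more. Where it says the series, first, only, none or still open, it means among the compounds named here.

Compound 2 `N[C@]1(C(=O)O)[C@H]2[C@@H](C[C@H]1OCc1ccc(Cl)cc1Cl)[C@]2(F)C(=O)O` stands with the lowest of the two numbers measured in an assay on CHO cells for binding affinity to metabotropic glutamate receptor 2 (Rattus norvegicus) (a higher number here means a weaker inhibitor, a lower number a stronger inhibitor), giving 3.89 nM. Its nearest neighbour, compound 1 `N[C@]1(C(=O)O)[C@H]2[C@@H](C[C@H]1OCc1cccc(F)c1F)[C@]2(F)C(=O)O`, gives 4.25 nM in this assay, and the step of a 1.1-fold lower number from compound 1 to compound 2 (0.04 log units; within the scatter) lies within the scatter. Compound 3 `N[C@]1(C(=O)O)[C@H]2[C@@H](C[C@H]1OCc1cccs1)[C@]2(F)C(=O)O` differs from compound 2 in one place: thiophen-2-yl in place of 2,4-dichlorophenyl on a saturated chain carbon bound to an oxygen on a saturated carbon. For the measured compounds named here, only one measured step bears on this exchange, a 1.1-fold lower number from compound 1 to compound 2 (0.04 log units; within the scatter), which swapped one substituted six-membered aromatic ring for another at the same place without moving the number beyond the scatter. Going by the values given here, no measured step removes both chlorines or brings in a five-membered aromatic ring with one hetero atom, so the evidence is thin. For compound 3 the expected step is a 1.4-fold higher number from compound 2 to compound 3 (0.15 log units; within the scatter), judged as no change beyond the scatter. Compound 3 is accordingly estimated at 5.5 nM, with a range from 2 nM to 16 nM.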

Compound 3, inhibition constant: 8.79 nM
Compound 3: the middle estimate sits 1.6-fold (0.20 log units) below what was measured; low and high end bracket the measured number.
By their numbers in this assay, from the lowest: compounds 2 and 1 (each within the scatter of the next); then compound 3.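

In this assay, the exchange at this place, on a saturated chain carbon bound to an oxygen on a saturated carbon, now moves the number beyond the scatter. Thiophen-2-yl gives a modest rise against both substituted phenyl groups (a 2.3-fold higher number from compound 2 to compound 3 (0.35 log units; beyond the scatter)) and (a 2.1-fold higher number from compound 1 to compound 3 (0.32 log units; beyond the scatter)), so this place does respond to the ring it carries, though the two steps are small. Nothing shown explains the rise.

The exchange changes ring size, brings in sulfur and removes the halogens all at once, so the compounds shown leave open which of these changes accounts for the step. An unsubstituted phenyl, a furan-2-yl or a chlorine-bearing thiophene in the same place would separate these changes.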